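Series notes: growth inhibition of liver cells, toward compound 4

The source may hold more compounds than are shown below. What is called first, only, known or untested is meant among the compounds shown, and "the series" means these compounds.

Measured so far:
compound 1 `Cc1ccccc1Nc1nc(NCc2ccncc2)ncc1Cl` — > 100000 nM
compound 2 `Cc1ccccc1Nc1nc(Nc2ccc(N3CCCCC3)cc2)ncc1Cl` — 5690 nM
compound 3 `CN1CCN(c2ccc(Nc3ncc(Cl)c(NCc4ccccc4)n3)nc2)CC1` — 20300 nM

All three were run in an ADME assay on L02 cells (Homo sapiens) for inhibition, read by CCK-8 assay, with a stated time of 48 h; on this read-out higher numbers stand for weaker inhibition of growth and lower numbers for stronger inhibition of growth. The value of compound 1 is a limit of the assay and not a number; it sits at the limit of > 100000 nM in this assay, at which 1 of the 3 values shown sits. Of the two numbers, compound 3 holds the higher one at 20300 nM; compound 2 gives 5690 nM, and the gap between these two numbers is beyond the usual scatter.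

Compound 4 `COc1cccc(Nc2nc(Nc3ccc(N4CCN(C)CC4)cn3)ncc2Cl)c1` has not been measured in this assay. Against compound 3 it shows one difference: 3-methoxyphenyl in place of benzyl on a nitrogen on an aromatic ring. For the measured compounds named here, no step between measured compounds covers this change. Compound 2 also carries an aromatic ring directly on the corresponding nitrogen and gives 5690 nM, but compound 2 and compound 3 differ in more than one place, so that pair only shows what its two values show.

The step from compound 3 to compound 4 is expected to move toward stronger inhibition of growth, by a modest amount that may still sit within the scatter, a 2.0-fold lower number from compound 3 to compound 4 (0.31 log units; beyond the scatter). Compound 4 is therefore estimated at 10000 nM, in the range 3000 nM to 35000 nM.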

Compound 4, concentration for 50% growth inhibition: 3470 nM
Compound 4: middle estimate off by 2.9-fold (0.46 log units), on the high side; the range from low to high includes it.
By their numbers in this assay, from the lowest: compounds 4 and 2 (each within the scatter of the next); then compound 3. At a limit, above all of these: compound 1.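

For the compounds shown here, compound 3 and compound 4 give the first one-place step, so the position can now be read: in this assay, 3-methoxyphenyl in place of benzyl on a nitrogen on an aromatic ring gives a 5.9-fold lower number from compound 3 to compound 4 (0.77 log units; beyond the scatter), which is a modest step but beyond the scatter. Going by these compounds alone, the growth-inhibition number therefore responds to this substituent, which the earlier compounds could not show because no two of them differed in one place only. The step is one case on one core, and nothing in hand says why the number moves with this change.

Going by these compounds, how an unsubstituted phenyl, a 3-aminophenyl or a 3-carboxyphenyl on this nitrogen would compare with 3-methoxyphenyl stays open, and with it how much of the step belongs to the methoxy group and how much to the exchange of benzylamino for an arylamino group. Also open, on these data alone, is whether a longer chain such as 2-phenylethyl would move the number in the opposite direction, and whether the same change would give a step of similar size on the other compounds.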